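Sulfur substituent changes on a shared core

The source may hold more compounds than are shown below. What is called first, only, known or untested is meant among the compounds shown, and "the series" means these compounds.

Compounds measured so far:
compound 1 `CC(C)c1n[nH]c2c(NCc3ccc(-c4ccccn4)cc3)nc(SCC(O)C(F)(F)F)nc12` gives 690 nM
compound 2 `CC(C)c1n[nH]c2c(NCc3ccc(-c4ccccn4)cc3)nc(SC[C@H](O)CN)nc12` gives 63 nM
compound 3 `CC(C)c1n[nH]c2c(NCc3ccc(-c4ccccn4)cc3)nc(SC3CCCC3O)nc12` gives 567 nM

In a functional assay on HT cells (Homo sapiens) for antiproliferative activity, read by fluorescence, with a stated time of 72 h (on this read-out lower numbers stand for stronger inhibition of growth and higher numbers for weaker inhibition of growth), compound 3 stands second highest of the three numbers; its nearest neighbour is compound 1, and the pair lie within the scatter, as a 1.2-fold lower number from compound 1 to compound 3 (0.09 log units; within the scatter) shows. Compound 2 is the one that stands apart: a 9.0-fold higher number from compound 2 to compound 3 (0.95 log units; beyond the scatter) and an 11-fold lower number from compound 1 to compound 2 (1.04 log units; beyond the scatter) are both beyond the scatter, and in each case the compound bearing an amine in the chain on the sulfur gives the lower number.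

Compound 4 `COCSc1nc(NCc2ccc(-c3ccccn3)cc2)c2[nH]nc(C(C)C)c2n1` differs from compound 3 only at the sulfur: methoxymethyl in place of 2-hydroxycyclopentyl on a sulfur. The group that enters carries neither the amine of compound 2 nor the hydroxyl that compounds 1 and 3 share. Among the compounds with values here, the steps that bear on this are a 1.2-fold lower number from compound 1 to compound 3 (0.09 log units; within the scatter), which was flat, and a 9.0-fold higher number from compound 2 to compound 3 (0.95 log units; beyond the scatter), which shows that a gain of the amine, not a change of the hydroxyl-bearing group, moved the number. Within the data shown here, no measured step removes the hydroxyl outright, so the direction is uncertain, and a step of modest size towards a higher number, or none beyond the scatter, is expected in this assay. Compound 4 is estimated at 900 nM, within 350 nM to 2500 nM, which means a 1.6-fold higher number from compound 3 to compound 4 (0.20 log units; within the scatter).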

Compound 4, concentration for 50% growth inhibition: 340 nM
Compound 4: middle estimate off by 2.6-fold (0.42 log units), on the high side; the whole stated range lies above it.
By their numbers in this assay, from the lowest: compound 2; then compounds 4, 3 and 1 (each within the scatter of the next, the first and the last beyond it).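

In this assay, within the data shown here, the step to methoxymethyl (a 1.7-fold lower number from compound 3 to compound 4 (0.22 log units; within the scatter)) lies within the scatter, so at this sulfur a group with no ring and 0 hydrogen-bond donors stands level with 2-hydroxycyclopentyl, something the earlier compounds, all of which carry a hydroxyl, could not show. Set against the chain of compound 1, the same group gives a lower number (a 2.0-fold lower number from compound 1 to compound 4 (0.31 log units; beyond the scatter)), a step beyond the scatter, so among these compounds a hydroxyl on the sulfur substituent is not needed for a number in this range. Among these compounds, compound 2 still stands apart (a 5.4-fold higher number from compound 2 to compound 4 (0.73 log units; beyond the scatter)), and with compound 4 in the set, the chain bearing the amine remains the only one whose number lies beyond the scatter from those of all the others.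

The compounds shown leave open whether an amine on a chain without a hydroxyl would give as low a number as compound 2, and how a carboxylic acid or a longer ether chain on the sulfur would read. Nothing measured here accounts for the place of compound 4 or for the distance of compound 2 from the rest.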